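The source may hold more compounds than are shown below. What is called first, only, known or untested is meant among the compounds shown, and "the series" means these compounds.

Compounds measured so far:
- Compound 1, `Cc1ccc(-n2nc(C(=O)Nc3ccc(Oc4ncnc5sccc45)c(F)c3)c(C)cc2=O)cc1`: > 40000 nM
- Compound 2, `O=C(Nc1ccc(Oc2ncnc3ccsc23)c(F)c1)c1nn(-c2ccc(F)cc2)ccc1=O`: 8230 nM

In a functional assay on A549 cells (Homo sapiens) for cytotoxicity, read by MTT assay, with a stated time of 72 h (a higher number here means a weaker inhibitor, a lower number a stronger inhibitor), compound 1 gives > 40000 nM, which is a limit of the assay and not a number. Compound 1 thus sits at the limit of > 40000 nM in this assay, at which 1 of the 2 values shown sits. For the measured compounds named here, compound 2 is the only compound with an actual number in this assay, where compound 2 gives 8230 nM. The compound not yet measured is compound 3, `O=C(Nc1ccc(Oc2ncnc3ccsc23)c(F)c1)c1nn(-c2ccccc2)ccc1=O`. It differs from compound 2 in one place only: hydrogen in place of fluoro on an aromatic carbon, so the 4-fluorophenyl on the core becomes a plain phenyl. Going by the values given here, no measured pair of compounds that differ in one place is available here, so the size of this step can only be guessed. Compound 3 is expected to lie close to compound 2, with the step from compound 2 to compound 3 estimated as a 1.2-fold higher number from compound 2 to compound 3 (0.08 log units; within the scatter), within the usual scatter. The estimate for compound 3 in this assay is 10000 nM, ranging from 4000 nM to 30000 nM.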

Compound 3, half-maximal inhibitory concentration: 19700 nM
Compound 3: middle estimate off by 2.0-fold (0.29 log units), on the low side; measured number inside the range.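

In this assay, for the compounds shown here, compound 2 and compound 3 form the first pair that differs in one place only, and that pair shows a 2.4-fold higher number from compound 2 to compound 3 (0.38 log units; beyond the scatter). Going from 4-fluorophenyl to phenyl therefore weakens the effect modestly, so what sits on this aromatic carbon does matter here, although the numbers give the size of the change and not its cause. Compound 3 still gives a real number and not a limit, so the full step can be read short of the ceiling of the assay: the limit of > 40000 nM in this assay, at which 1 of the 3 values shown sits.

Still open, going by these compounds, is whether fluoro is special at this place, or whether chloro, methoxy or an amine there would do as well or better. Compound 1 differs from compound 2 in more than one place, so it cannot settle this.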